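The compounds below may be only part of what the source reports. "The series", "measured", "known", "first", "only" and "open" are said of these compounds alone.

Series notes, step from compound 2 to compound 3.

Compound 1 `CC(=O)NC1CCC(CN2CCN(c3cc(=O)c4cc(C(F)(F)F)cc([N+](=O)[O-])c4s3)CC2)CC1` is the reference point: in an ADME assay on cells (Hepatocyte, Homo sapiens) for metabolic stability, with a stated time of 30 min (on this read-out higher numbers stand for a more stable compound and lower numbers for a less stable compound), compound 1 gives 86.8%. Within the data shown here, compound 2 `O=C(OC1CCC(CN2CCN(c3cc(=O)c4cc(C(F)(F)F)cc([N+](=O)[O-])c4s3)CC2)CC1)c1ccc(F)cc1` carries ((4-fluorophenyl)carbonyl)oxy in place of acetamido on a saturated ring carbon, and in this assay compound 2 gives 3%, the lower of the two numbers measured so far; the only measured step, a number 83.8 percentage points lower from compound 1 to compound 2 (beyond the scatter), is far beyond the scatter.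

Compound 3 `O=C(OC1CCC(CN2CCN(c3cc(=O)c4cc(C(F)(F)F)cc([N+](=O)[O-])c4s3)CC2)CC1)c1ccccc1` differs from compound 2 by hydrogen in place of fluoro on an aromatic carbon. Among the measured compounds shown here, no measured step touches this position: the one step measured concerns the substituent on the saturated ring carbon, not the aromatic ring. With nothing to rest on, a step no larger than the scatter is expected for a number 2 percentage points higher from compound 2 to compound 3 (within the scatter), in either direction, and the value of compound 2 already sits near the floor of this assay. Compound 3 is therefore estimated at 5%, range 1% to 18%.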

Compound 3, percent of the compound remaining: 56.4%
For compound 3 the middle estimate is 51.4 percentage points below the measured one; measured number above the stated range.
By their numbers in this assay, from the lowest: compound 2; then compound 3; then compound 1.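

In this assay, among these compounds, the aromatic carbon para to a large group proves sensitive: hydrogen in place of fluoro gives a number 53.4 percentage points higher from compound 2 to compound 3 (beyond the scatter), so a single-atom change here is large, whereas the earlier compounds showed a large step only for the whole substituent on the saturated ring carbon. Without the fluoro, benzoyloxy in place of acetamido still gives a number 30.4 percentage points lower from compound 1 to compound 3 (beyond the scatter), so the change on the saturated ring carbon stays large, but the fluoro accounts for much of the low number of compound 2. Nothing available explains either step.

Going by these compounds, it remains open whether other groups on that aromatic carbon, such as chloro or methoxy, would stand with fluoro or with hydrogen. Also open, on these data alone, is how benzamido would stand on the saturated ring carbon, compared with benzoyloxy and acetamido.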